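This account rests on a few compounds, and the source may have more. Where it says the series, first, only, none or still open, it means among the compounds named here.

Working notes on the series. Within the data shown here, in an in vitro ADME assay on microsomes from liver (Homo sapiens) for metabolic stability, read by LC-MS, using NADPH, tested at 1 uM, in the presence of a further agent that is not named here (on this read-out lower numbers stand for a shorter-lived compound and higher numbers for a longer-lived compound), compound 1 `COc1ccc(C(=O)/C=C/c2ccc(OCCNc3ccnc4cc(Cl)ccc34)c(OC)c2)c(OC)c1` gives 0.292 h, the lowest of the two numbers measured so far. Compound 2 `COc1ccc(C(=O)/C=C/c2cc(CN3CCN(c4ccnc5cc(Cl)ccc45)CC3)c(O)c(OC)c2)c(OC)c1` gives 0.617 h in this assay, a higher number than compound 1 shows and beyond the usual scatter. Among the measured compounds shown here, no step between measured compounds that differ in one place is available, and the two measured compounds differ in several places at once, so the move to compound 3 `COc1cc(/C=C/C(C)=O)ccc1OCCNc1ccnc2cc(Cl)ccc12` rests on the structural change alone: methyl in place of 2,4-dimethoxyphenyl on a carbonyl carbon, the (2,4-dimethoxyphenyl)carbonyl becoming an acetyl. For the measured compounds named here, nothing among the measured compounds tests a change of this kind. The change is expected to give a step of a 1.4-fold higher number from compound 1 to compound 3 (0.14 log units; within the scatter) in this assay, a small rise at most, quite possibly within the scatter. For compound 3 the expected half-life is 0.4 h, with a range from 0.2 h to 0.9 h.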

Compound 3, half-life in the Homo sapiens assay: 0.175 h
Compound 3: middle estimate off by 2.3-fold (0.36 log units), on the high side, and the stated range ends above it.
By their numbers in the Homo sapiens assay, from the lowest: compounds 3 and 1 (each within the scatter of the next); then compound 2.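

In the Homo sapiens assay, methyl in place of 2,4-dimethoxyphenyl on a carbonyl carbon gives a 1.7-fold lower number from compound 1 to compound 3 (0.22 log units; within the scatter), so this place tolerates the loss of the whole aromatic ring without a half-life difference that can be told from the scatter. The earlier compounds shown here could not show this, as they differ in several places at once. In a physicochemical assay for solubility, in phosphate buffer, at pH 6.5 (on this read-out lower numbers stand for lower solubility and higher numbers for higher solubility), compound 1 gives 3.1 ug/mL and compound 3 gives 6.3 ug/mL, so the same change does separate the pair, with the higher solubility on the methyl side: the measured solubility of compound 1, 3.1 ug/mL, and of compound 3, 6.3 ug/mL, a 2.0-fold higher number (0.31 log units; beyond the scatter).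

This single pair leaves open whether the higher solubility follows from removing the ring or from removing the two methoxy groups, which an unsubstituted phenyl on the carbonyl carbon would separate. It also leaves open how an amine or a carboxylic acid at this place would behave on half-life and solubility.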